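Replacing a cyclohexyl amide with an aryl amide

A few compounds are considered here, and "the series" means these few. Any claim that something is new, unique, unknown or untested is made for them only; others in the source may bear on it.

In a functional assay on SW480 cells (Homo sapiens) for cytotoxicity, read by MTT assay, with a stated time of 24 h (a lower number here means a stronger inhibitor, a higher number a weaker inhibitor), compound 1 `C=CC1=C(C(=O)NC2CCCCC2)C(c2ccc(OC)cc2)OC1` stops at the limit of the measurement, > 100000 nM, so no number is known for it. Compound 2 `C=CC1=C(C(=O)NC2CCCCC2)C(c2ccc(F)cc2)OC1`, made by a fluoro in place of methoxy on an aromatic carbon, also stops at the limit, > 100000 nM. The step between them is therefore a step that the two limits leave unreadable from compound 1 to compound 2. Among the compounds with values here, compound 3 `C=CC1=C(C(=O)NCCCCC)C(c2ccc(Cl)c(Cl)c2)OC1` is the one compound with a number: in this assay compound 3 gives 27500 nM. The common feature so far is the limit of > 100000 nM in this assay, at which 2 of the 3 values shown sit.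

Compound 4 `C=CC1=C(C(=O)Nc2ccc(OCC)cc2)C(c2ccc(OC)cc2)OC1` differs from compound 1 in one place: 4-ethoxyphenyl in place of cyclohexyl on an amide-type nitrogen. Within the data shown here, none of the measured steps changes the group on the amide-type nitrogen, so no step bears directly on this change. Compound 1 itself is at the limit, and compound 3 shows that a different combination of groups can reach a measurable, still weak, number. Compound 4 is expected to remain weak, with a step of an at least 1.2-fold lower number from compound 1 to compound 4 (0.09 log units; that floor lies within the scatter) expected from compound 1. The estimate for compound 4 is 80000 nM, with a range from 20000 nM to 300000 nM.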

Compound 4, half-maximal inhibitory concentration: > 100000 nM
Compound 4 gave a limit, no number; the forecaster's own chance of this, stated with the estimate: 60%; middle value at least 1.2-fold (0.09 log units) from the limit.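

In this assay compound 4 gives > 100000 nM, a limit and not a number. Compound 1 also stops at a limit, so no step can be read between the two compounds. The compounds shown leave open how much 4-ethoxyphenyl in place of cyclohexyl on the amide-type nitrogen changes the activity.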